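The compounds below may be only part of what the source reports. "The series", "measured", "known", "first", "only" and "open" are said of these compounds alone.

In a functional assay on MCF7 cells (Homo sapiens) for inhibition, read by sulforhodamine B assay, with a stated time of 48 h (on this read-out lower numbers stand for stronger inhibition and higher numbers for weaker inhibition), compound 1 (`COc1ccc(C(c2ccccc2O)c2cccc3ccccc23)c(OC)c1OC`) gives 16600 nM. Compound 2 (`C=CCOC(c1ccc(OC)c(OC)c1OC)c1cccc2ccccc12`) gives only a limit of the assay, > 20000 nM, so no exact number is available for it. Compound 3 (`COc1ccc(C(OCc2ccc(C)cc2)c2cccc3ccccc23)c(OC)c1OC`) keeps the shared core and carries (4-methylbenzyl)oxy where compound 2 has allyloxy, with 4-methylphenyl in place of vinyl on a saturated chain carbon bound to an oxygen on a saturated carbon. For the measured compounds named here, one measured step bears on this change, since it also involves the allyloxy group: an at least 1.2-fold higher number from compound 1 to compound 2 (0.08 log units; that floor lies within the scatter). Going by the values given here, that step gives only a floor, which lies within the scatter, and the data hold no measured step for a change at the vinyl end of the chain. Among the compounds with values here, with an at least 1.2-fold higher number from compound 1 to compound 2 (0.08 log units; that floor lies within the scatter) as the only guide, no step beyond the scatter is expected in this assay. The expected step is a number no higher from compound 2 to compound 3 (the limit leaves the size open). For compound 3 the estimated value is 20000 nM, with an expected range from 8000 nM to 50000 nM.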

Compound 3, half-maximal inhibitory concentration: 10700 nM
For compound 3 the middle estimate is 1.9-fold (0.27 log units) above the measured one, and the stated range covers the measured number.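

Compound 3 gives an exact number for an oxygen-bound chain at this carbon, which compound 2 did not. Putting 4-methylphenyl in place of vinyl gives an at least 1.8-fold lower number from compound 2 to compound 3 (0.27 log units; that floor lies within the scatter), and putting (4-methylbenzyl)oxy in place of 2-hydroxyphenyl gives a 1.6-fold lower number from compound 1 to compound 3 (0.19 log units; within the scatter), so neither step establishes a change beyond the scatter. Compound 2 is held at a limit, and its step carries only a floor: the limit of > 20000 nM in this assay, at which 1 of the 3 values shown sits.

On these data alone, the true size of the change from vinyl to 4-methylphenyl therefore remains unknown. As far as these compounds go, it also remains open whether a longer chain, or an amine or a carboxylic acid in place of 4-methylphenyl, on a saturated chain carbon bound to an oxygen on a saturated carbon would move the number beyond the scatter.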